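The source may report more compounds than this note shows. Statements on the series, on what has been measured and on what is new or still open speak of the compounds shown alone.

Working notes on the series in a functional assay on MIA PaCa-2 cells (Homo sapiens) for inhibition, read by MTT assay, with a stated time of 3 days; a lower number here means a stronger inhibitor, a higher number a weaker inhibitor.

Compound 1, `CCOC(=O)[C@@H]1CCCN(S(=O)(=O)c2ccc(S(=O)(=O)N(CC)CC)nc2)C1`, gives in this assay a value of > 10000 nM, which is a limit of the assay and not a number. Compound 2, `CCOC(=O)N1CCC[C@H](S(=O)(=O)c2ccc(S(=O)(=O)N(CC)CC)cc2)C1`, gives in this assay > 10000 nM, again a limit rather than a number. Among the compounds with values here, compound 2 therefore stands at the limit of > 10000 nM in this assay, at which 2 of the 2 values shown sit; no measured compound in the set shows a numerical value, so no step between measured compounds can be sized, and nothing here separates compound 1 from compound 2.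

The next compound is compound 3, `CCOC(=O)N1CCC[C@@H](S(=O)(=O)c2ccc(S(=O)(=O)N(CC)CC)cc2)C1`. The change from compound 2 to compound 3 is the two compounds have the same atoms and bonds and differ only in configuration as drawn: 1 of 1 stereo elements differ; a stereocentre at a saturated ring carbon is drawn S in compound 2 and R in compound 3. With compound 2 sitting at its limit > 10000 nM, the step from compound 2 to compound 3 is expected to be no more than the scatter, with the result most likely again a limit. For compound 3 the estimate in this assay is 20000 nM, within a range from 5000 nM to 80000 nM, meaning an expected step that the limit leaves unreadable from compound 2 to compound 3.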

Compound 3, half-maximal inhibitory concentration: > 10000 nM
Compound 3: a limit, no number (the forecaster's own chance of this, stated with the estimate: 80%); the middle value is on the limit's open side.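

In this assay compound 3 gives > 10000 nM, again a limit and not a number, so the step from compound 2 to compound 3 cannot be read. The compounds shown leave open whether the drawn configuration at the saturated ring carbon affects inhibition at all.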